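A few compounds are considered here, and "the series" means these few. Any claim that something is new, unique, unknown or untested is made for them only; others in the source may bear on it.

The three measured compounds share one core. In a functional assay on the whole organism (strain Wistar) for inhibition, with Rattus norvegicus as the target, read by paw edema, with a stated time of 4 h, at a dose of 100 mg/kg (on this read-out lower numbers stand for less inhibition and higher numbers for more inhibition at the one dose given (going by the name of the read-out)), compound 1 `COc1cc2c(cc1OC)C(CC(=O)Nc1ccccc1)CC2` gives 37.5%. Compound 2 `COc1cc2c(cc1OC)C(CC(=O)Nc1ccc(Br)cc1)CC2` gives 40.6%, and compound 3 `COc1cc2c(cc1OC)C(CC(=O)Nc1ccccc1C)CC2` gives 25%. Compound 3 stands lowest of the three: the steps of a number 12.5 percentage points lower from compound 1 to compound 3 (beyond the scatter) and a number 15.6 percentage points lower from compound 2 to compound 3 (beyond the scatter) both lie beyond the scatter, whereas a number 3.1 percentage points higher from compound 1 to compound 2 (within the scatter) stays within it. Compound 4 `COc1cc2c(cc1OC)C(CC(=O)Nc1cccc(C)c1)CC2` differs from compound 3 in one place: 3-methylphenyl in place of 2-methylphenyl on an amide-type nitrogen. Within the data shown here, no measured step moves the methyl from one place on this ring to another, so none bears directly on the change. On these data alone, the nearest guide is a number 12.5 percentage points lower from compound 1 to compound 3 (beyond the scatter), which shows that methyl in place of hydrogen on an aromatic carbon lowered the read-out modestly; whether 3-methylphenyl behaves like 2-methylphenyl is unknown. The step is therefore expected to be small, a number 7 percentage points higher from compound 3 to compound 4 (within the scatter), perhaps recovering part of the way toward compound 1. Compound 4 is estimated to give 32%, with a range from 20% to 45%.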

Compound 4, a percentage reported as inhibition, in the whole organism at one dose (the size of the read-out at that dose, not a potency): 40.6%
The estimate for compound 4 lay 8.6 percentage points below the measured number; measured number inside the range.
By their numbers in this assay, from the lowest: compound 3; then compounds 1, 2 and 4 (each within the scatter of the next).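

In this assay, among these compounds, moving the methyl on the ring gives a number 15.6 percentage points higher from compound 3 to compound 4 (beyond the scatter), so the place of the methyl on this ring counts, which no earlier step could show. Methyl in place of hydrogen does not lower the read-out at every place: with 3-methylphenyl the step is a number 3.1 percentage points higher from compound 1 to compound 4 (within the scatter), and the exchange for 4-bromophenyl gives no change at the digits printed from compound 2 to compound 4 (within the scatter), so among these compounds only 2-methylphenyl stands apart. No measured evidence is at hand that explains this difference between the two places.
The compounds shown leave open whether chlorine or methoxy in place of the methyl would follow the same course at these places. They also leave open how an amine or a carboxylic acid on this ring would read.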